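The source may hold more compounds than are shown below. What is called first, only, known or untested is meant among the compounds shown, and "the series" means these compounds.

Two compounds that share one core have numbers in a functional assay on HCT-116 cells (Homo sapiens) for inhibition, read by MTT assay, with a stated time of 72 h; on this read-out higher numbers stand for weaker inhibition and lower numbers for stronger inhibition. Compound 1 `COc1cc2c(Oc3ccc(NC(=O)c4nn(-c5ccccc5C)cc(C)c4=O)cc3)ccnc2cc1OCCCC(=O)NO` gives 640 nM, and compound 2 `COc1cc2c(Oc3ccc(NC(=O)c4nn(-c5ccc(C)cc5C)cc(C)c4=O)cc3)ccnc2cc1OCCCCCCC(=O)NO` gives 440 nM. These two values lie within the scatter of each other, so compound 2 stands level with compound 1 on the numbers shown. Compound 3 `COc1cc2c(Oc3ccc(NC(=O)c4nn(-c5cccc(C)c5)cc(C)c4=O)cc3)ccnc2cc1OCCCCCCC(=O)NO` departs from compound 2 in one place, with 3-methylphenyl in place of 2,4-dimethylphenyl on an aromatic nitrogen. For the measured compounds named here, no pair of measured compounds differs in one place only, so the data do not size this change directly. No shift beyond the scatter is expected in this assay, and neither direction is favoured. The expected outcome is a 1.0-fold higher number from compound 2 to compound 3 (0.01 log units; within the scatter). For compound 3 the estimated value is 450 nM, within an expected range of 180 nM to 1100 nM.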

Compound 3, half-maximal inhibitory concentration: 370 nM
Estimate against measurement, compound 3: 1.2-fold (0.09 log units) above; the range from low to high includes it.
By their numbers in this assay, from the lowest: compounds 3, 2 and 1 (each within the scatter of the next).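

For the compounds shown here, the swap of 2,4-dimethylphenyl for 3-methylphenyl on the aromatic nitrogen gives the first step between compounds that differ in one place, and in this assay it reads as a 1.2-fold lower number from compound 2 to compound 3 (0.08 log units; within the scatter). Going from 8 heavy atoms to 7 in this aryl group, and from two methyl groups to one, therefore leaves the two compounds level on this read-out, so this position accepts at least these two methyl-substituted phenyl groups without a separation in the numbers. No measurement on hand gives a reason for this outcome.

From the compounds shown here alone, whether a ring without any methyl group, such as plain phenyl, 4-fluorophenyl or a pyridyl ring, would also stay level at this position remains open. So does whether this swap would read the same with the hydroxamic acid chain of compound 1 in place of the chain shared by compound 2 and compound 3.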